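Notes on the step to compound 3

The source may report more compounds than this note shows. Statements on the series, on what has been measured and on what is new or still open speak of the compounds shown alone.

Measured so far in an ADME assay on the whole organism for pharmacokinetics, with Rattus norvegicus as the target, at a dose of 5 mg/kg by the oral route (on this read-out lower numbers stand for lower exposure and higher numbers for higher exposure at the dose given), and nothing else:
- compound 1 `CO[C@H]1CC[C@@H](CN2CC(=O)Nc3ncc(-c4ccc(C(C)(C)O)nc4)nc32)CC1` gives "not determined" (no result reported)
- compound 2 `CO[C@H]1CC[C@@H](N2CC(=O)Nc3ncc(-c4ccc(C(C)(C)O)nc4)nc32)CC1` gives 10600 ng.h/mL

Among the measured compounds shown here, compound 2 carries the only number in this small set, so it cannot be ranked against anything, and compound 1 offers no comparison. Still to be measured is compound 3 `CO[C@H]1CC[C@H](CN2CC(=O)Nc3ncc(-c4ccc(C(C)(C)O)nc4)nc32)CC1` in the same read-out. The change is (4-methoxycyclohexyl)methyl in place of 4-methoxycyclohexyl on a nitrogen on an aromatic ring in a ring and amounts to (4-methoxycyclohexyl)methyl in place of 4-methoxycyclohexyl on a nitrogen on an aromatic ring in a ring.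

For the measured compounds named here, no measured pair shows what this kind of change does, so the expectation is anchored only on compound 2 at 10600 ng.h/mL and remains a judgment. A fall in this assay somewhat beyond the usual scatter is expected, although a result within the scatter would be no surprise. The estimated change is a 2.4-fold lower number from compound 2 to compound 3 (0.37 log units; beyond the scatter) on this basis. For compound 3 the estimated value is 4500 ng.h/mL with an expected range from 1300 ng.h/mL to 11000 ng.h/mL in this read-out.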

Compound 3, area under the concentration-time curve: 2980 ng.h/mL
Compound 3: middle estimate off by 1.5-fold (0.18 log units), on the high side, and the stated range covers the measured number.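

Among the compounds shown here, at the ring nitrogen, this is the first readable step: in this assay, (4-methoxycyclohexyl)methyl in place of 4-methoxycyclohexyl gives a 3.6-fold lower number from compound 2 to compound 3 (0.55 log units; beyond the scatter). Exposure at the dose given therefore responds to what sits on this nitrogen, and of the two groups with a number, the 4-methoxycyclohexyl of compound 2 gives the higher value. The step cannot yet be assigned to the added methyl link alone, as compound 1, the one partner that could isolate configuration, gives "not determined" (no result reported) in this assay, and the relation between the two stands as follows: the fact that compounds 1 and 3 differ only in the configuration as drawn

Open, from the compounds shown here alone, is whether the fall continues with a longer chain on the nitrogen, such as a 2-(4-methoxycyclohexyl)ethyl group, or whether it is specific to the single added carbon. For the compounds shown here, also open is how exposure in this assay would respond if the methoxy on the cyclohexyl ring were replaced by a hydroxyl or an amine, and the single pair gives no indication of what lies behind the step.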